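The compounds below may be only part of what the source reports. "The series", "measured", "known", "first", "only" and "open" are said of these compounds alone.

Measured compounds:
compound 1 `CC(C)=NNc1nc(-c2cccc([N+](=O)[O-])c2)cs1` gives 716 nM in an assay on isolated protein for inhibition of Amine oxidase [flavin-containing] B (Homo sapiens), read by fluorescence, with a stated time of 20 min; on this read-out lower numbers stand for stronger inhibition and higher numbers for weaker inhibition;
compound 2 `CC/C(C)=N\Nc1nc(-c2cccc([N+](=O)[O-])c2)cs1` gives 351 nM in this assay;
compound 3 `CCC(CC)=NNc1nc(-c2cccc([N+](=O)[O-])c2)cs1` gives 53 nM in this assay.

Compound 1 has the highest number of the three in this assay; the nearest to it is compound 2, the furthest compound 3. Both steps away from compound 1 are beyond the scatter, so compound 1 stands as the weakest of the measured set.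

Compound 4 `C/C(CC(C)C)=N/Nc1nc(-c2cccc([N+](=O)[O-])c2)cs1` differs from compound 1 in one place: isopropyl in place of hydrogen on a saturated chain carbon bound to a carbon with a double bond to nitrogen. The shared core with its nitro-bearing aryl group and the hydrazone linkage are unchanged.

For the measured compounds named here, two measured steps bear on this change. Adding a single methyl at the same place gives a 2.0-fold lower number from compound 1 to compound 2 (0.31 log units; beyond the scatter). Enlarging both branches of the hydrazone substituent gives a 14-fold lower number from compound 1 to compound 3 (1.13 log units; beyond the scatter), and the further step a 6.6-fold lower number from compound 2 to compound 3 (0.82 log units; beyond the scatter) shows that more carbon on this substituent has so far gone with lower numbers. Compound 4 adds three carbons at one branch only, so a lower number than compound 1 is expected, with a size likely between those two steps rather than beyond the larger one.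

Compound 4 is therefore expected to give 150 nM in this assay, with a range of 50 nM to 450 nM. This estimate corresponds to an expected step of a 4.8-fold lower number from compound 1 to compound 4 (0.68 log units; beyond the scatter).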

Compound 4, half-maximal inhibitory concentration: 12 nM
Compound 4: middle estimate off by 13-fold (1.10 log units), on the high side, outside the stated range (below it).
By their numbers in this assay, from the lowest: compound 4; then compound 3; then compound 2; then compound 1.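

In this assay, isopropyl on the saturated chain carbon bound to a carbon with a double bond to nitrogen gives a larger drop than any earlier change at this substituent (a 60-fold lower number from compound 1 to compound 4 (1.78 log units; beyond the scatter)), and isopropyl in place of methyl at the same place also gives a large step (a 29-fold lower number from compound 2 to compound 4 (1.47 log units; beyond the scatter)). The earlier compounds shown here left open whether lengthening both branches was needed, but growth on one branch alone goes lower than compound 3 (a 4.4-fold lower number from compound 3 to compound 4 (0.65 log units; beyond the scatter)), so within these four compounds, enlargement of both branches is not required for a low number. No measurement at hand gives a reason for the size of these steps.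

The compounds shown leave open whether the trend with added carbon continues or reverses with a still larger group on this branch, such as tert-butyl, cyclohexyl or phenyl. They also leave open whether this branch tolerates anything other than carbon and hydrogen, such as a hydroxyl group or an amine at the end of the chain.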